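The source may hold more compounds than are shown below. What is called first, only, known or untested is meant among the compounds shown, and "the series" means these compounds.

Going by the values given here, compound 3 `O=C([C@@H]1CCCN1C(=O)c1ccncc1)N1CCC(NS(=O)(=O)c2cc(S(=O)(=O)c3ccccc3)ccc2C(F)(F)F)CC1` is one of three compounds measured in an assay on isolated protein for binding affinity to secreted frizzled-related protein 1 (Homo sapiens), read by fluorescence (on this read-out lower numbers stand for stronger inhibition and higher numbers for weaker inhibition), where compound 3 gives 70 nM. Compound 2 `CN(C)CC(=O)N1CCC[C@H]1C(=O)N1CCC(NS(=O)(=O)c2cc(S(=O)(=O)c3ccccc3)ccc2C(F)(F)F)CC1` gives 90 nM in this assay, and compound 1 `CC(C)(C)C(=O)N1CCC[C@H]1C(=O)N1CCC(NS(=O)(=O)c2cc(S(=O)(=O)c3ccccc3)ccc2C(F)(F)F)CC1` gives 40 nM. Compound 3 is separated from its neighbours by a 1.3-fold lower number from compound 2 to compound 3 (0.11 log units; within the scatter) and by a 1.8-fold higher number from compound 1 to compound 3 (0.24 log units; within the scatter); only a 2.3-fold higher number from compound 1 to compound 2 (0.35 log units; beyond the scatter) reaches beyond the scatter. Compound 4 `O=C([C@@H]1CCCN1C(=O)N1CCOCC1)N1CCC(NS(=O)(=O)c2cc(S(=O)(=O)c3ccccc3)ccc2C(F)(F)F)CC1` differs from compound 3 by morpholin-4-yl in place of pyridin-4-yl on a carbonyl carbon. The three measured steps all concern substituents on this same carbonyl carbon, and all were small, so the step from compound 3 to compound 4 is expected to be small as well, a 1.1-fold higher number from compound 3 to compound 4 (0.06 log units; within the scatter), with no clear direction. Compound 4 is therefore estimated to give 80 nM in this assay, within a range of 35 nM to 180 nM.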

Compound 4, half-maximal inhibitory concentration: 40 nM
The estimate for compound 4 lay 2.0-fold (0.30 log units) above the measured number; the measured number falls inside the stated range.
By their numbers in this assay, from the lowest: compounds 1, 4, 3 and 2 (each within the scatter of the next, the first and the last beyond it).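

In this assay, morpholin-4-yl, the only non-aromatic ring among the groups on this carbonyl carbon, stays within the scatter of pyridin-4-yl (a 1.8-fold lower number from compound 3 to compound 4 (0.24 log units; within the scatter)) and of tert-butyl (no change at the digits printed from compound 1 to compound 4 (within the scatter)). Only (dimethylamino)methyl stands apart from it (a 2.3-fold lower number from compound 2 to compound 4 (0.35 log units; beyond the scatter)), so compound 2 now differs beyond the scatter from both compound 1 and compound 4. No measurement shown here bears on the reason for these numbers. As far as these compounds go, what a carboxylic acid or a longer alkyl chain on this carbonyl carbon would give remains open. So does whether a primary amine would match the (dimethylamino)methyl group.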